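A few compounds are considered here, and "the series" means these few. Any claim that something is new, unique, unknown or untested is made for them only; others in the source may bear on it.

Compound 1 `CNC(=O)N1CCCc2ccc(NC(=O)c3ccc(-c4cc[nH]n4)cc3)cc21` gives 92.5% in a functional assay on MV4-11 cells (Homo sapiens) for antiproliferative activity, with a stated time of 6 days, tested at 1.56 uM; on this read-out lower numbers stand for a weaker effect and higher numbers for a stronger effect at the one concentration tested.
Compound 2 `CNC(=O)N1CCCc2ccc(NC(=O)c3ccc(-c4ccn(C)n4)cc3)cc21` gives 72.2% in this assay.
Compound 3 `CNC(=O)N1CCCc2ccc(NC(=O)c3ccc(-c4cn[nH]c4)cc3)cc21` gives 73.5% in this assay.

All three share one core and differ only in the small aromatic ring at its far end. On these numbers compound 3 stands second highest of the three: its nearest neighbour is compound 2, the two lying within the usual scatter of each other, and the only clear gap is to compound 1, as the step of a number 19 percentage points lower from compound 1 to compound 3 (beyond the scatter) shows.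

The step to compound 4 `CNC(=O)N1CCCc2ccc(NC(=O)c3ccc(-c4cccnc4)cc3)cc21` changes that ring again: pyridin-3-yl in place of 1H-pyrazol-4-yl on an aromatic carbon. Among the measured compounds shown here, two measured steps bear on it. The step of a number 20.3 percentage points lower from compound 1 to compound 2 (beyond the scatter) takes away the hydrogen on the ring nitrogen, the one hydrogen-bond donor, and compound 4 likewise has no donor. The step of a number 19 percentage points lower from compound 1 to compound 3 (beyond the scatter) shows that changing where the ring is joined lowers the number by a similar amount. Yet compound 2 and compound 3, one without a donor and one with, give much the same number, so the donor alone does not decide the outcome. For the measured compounds named here, no measured compound carries a six-membered ring in this place. A modest drop, or no change beyond the scatter, is expected, with a wide range. Compound 4 is therefore estimated at 60%, between 35% and 85%. The expected step is a number 13.5 percentage points lower from compound 3 to compound 4 (beyond the scatter).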

Compound 4, a percentage reported as inhibition, at one concentration (the size of the read-out at that concentration, not a potency): 62.5%
Compound 4: middle estimate off by 2.5 percentage points, on the low side; the measured number falls inside the stated range.
By their numbers in this assay, from the lowest: compounds 4, 2 and 3 (each within the scatter of the next, the first and the last beyond it); then compound 1.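

The position accepts a six-membered aromatic ring: with pyridin-3-yl, compound 4 still gives 62.5% in this assay, although replacing 1H-pyrazol-4-yl brings a number 11 percentage points lower from compound 3 to compound 4 (beyond the scatter) and so the new ring does not match the five-membered ring of compound 3 on this read-out. The largest gap among these compounds is a number 30 percentage points lower from compound 1 to compound 4 (beyond the scatter), which leaves the 1H-pyrazol-3-yl ring of compound 1 clearly ahead of all three other rings, while a number 9.7 percentage points lower from compound 2 to compound 4 (within the scatter) means that 1-methyl-1H-pyrazol-3-yl and pyridin-3-yl cannot be told apart here. Nothing measured explains why the rings fall in this order, so the numbers record the differences without giving a reason for them.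

The compounds shown leave open how a plain phenyl ring, which has no ring nitrogen, or pyridin-4-yl, with its nitrogen placed differently, would compare with compound 4. They also leave open what an amine or a carboxylic acid added to the 1H-pyrazol-3-yl ring of compound 1 would do to its high read-out.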